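Benzyl Ether at the Phenolic Oxygen: Expected Electroshock Dose

The source may hold more compounds than are shown below. What is called first, only, known or untested is meant among the compounds shown, and "the series" means these compounds.

Measured compounds:
compound 1 `CCCCOc1cccc(/C=N/n2c(-c3ccccc3)nc3ccccc3c2=O)c1` gives 100 mg/kg
compound 2 `O=c1c2ccccc2nc(-c2ccccc2)n1/N=C/c1cccc(O)c1` gives 100 mg/kg
compound 3 `CCOc1cccc(/C=N/n2c(-c3ccccc3)nc3ccccc3c2=O)c1` gives 100 mg/kg

These doses come from a functional assay on the whole organism (strain albino CF-1) with Mus musculus as the target, in the maximal electroshock model, with a stated time of 4 h; a lower number here means that less compound is needed, a higher number that more compound is needed for the effect. Compound 2 stands level with compound 1 and compound 3 in this assay: no change at the digits printed from compound 1 to compound 2 (within the scatter), no change at the digits printed from compound 2 to compound 3 (within the scatter), and no change at the digits printed from compound 1 to compound 3 (within the scatter). The unmeasured compound 4 `O=c1c2ccccc2nc(-c2ccccc2)n1/N=C/c1cccc(OCc2ccccc2)c1` differs from compound 2 by benzyl in place of hydrogen on an oxygen on an aromatic ring. For the measured compounds named here, the steps that bear on this change are the swaps of hydrogen, ethyl and butyl on the same oxygen on an aromatic ring, and neither no change at the digits printed from compound 1 to compound 2 (within the scatter) nor no change at the digits printed from compound 2 to compound 3 (within the scatter) moved the dose beyond the scatter. A step of no change at the digits printed from compound 2 to compound 4 (within the scatter) is therefore expected, that is, none beyond the scatter. Compound 4 is estimated at 100 mg/kg, with a range from 50 mg/kg to 300 mg/kg.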

Compound 4, minimum effective dose: 300 mg/kg
Beside the measured number, compound 4's estimate is 3.0-fold (0.48 log units) below it; measured number inside the range.
By their numbers in this assay, from the lowest: compounds 1, 2 and 3 (each within the scatter of the next); then compound 4.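

In this assay, for the compounds shown here, benzyl is the first group on the oxygen on an aromatic ring to move the number beyond the scatter: a 3.0-fold higher number from compound 2 to compound 4 (0.48 log units; beyond the scatter), a 3.0-fold higher number from compound 3 to compound 4 (0.48 log units; beyond the scatter) and a 3.0-fold higher number from compound 1 to compound 4 (0.48 log units; beyond the scatter). This position therefore tolerates hydrogen, ethyl and butyl at one level, but it does not accept every group equally. Nothing shown here explains this rise.

Still open, as far as these compounds go, is whether the rise comes from the aromatic ring of benzyl or would also appear with a non-aromatic group. A longer chain such as hexyl, or a chain ending in an amine, would help separate these possibilities.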